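A few compounds are considered here, and "the series" means these few. Any claim that something is new, unique, unknown or untested is made for them only; others in the source may bear on it.

Working notes on the series in a functional assay on HeLa cells (Homo sapiens) for antiproliferative activity, read by sulforhodamine B assay, with a stated time of 72 h; a lower number here means a stronger inhibitor, a higher number a weaker inhibitor. Compound 1 `COc1ccc(C)cc1NC(=S)N/N=C/c1ccc2ccccc2n1` gives only a limit of the assay, > 100000 nM, which is the limit of > 100000 nM in this assay, at which 1 of the 3 values shown sits. Within the data shown here, compound 2 `S=C(N/N=C/c1ccc2ccccc2n1)Nc1cccc(Cl)c1` gives 52500 nM, the highest of the two numbers measured so far. Compound 3 `Cc1csc2sc(/C=N/NC(N)=S)c(C)c12`, built on a different core, gives 1120 nM; the gap between compound 3 and compound 2 lies beyond the scatter. Compound 4 `S=C(N/N=C/c1ccc2ccccc2n1)Nc1ccc(Cl)cc1` differs from compound 2 by 4-chlorophenyl in place of 3-chlorophenyl on an amide-type nitrogen. Among the measured compounds shown here, no measured pair in the set isolates a change of this kind, so the expected step from compound 2 to compound 4 is modest, a 1.3-fold lower number from compound 2 to compound 4 (0.12 log units; within the scatter), and may lie within the scatter in either direction. Compound 4 is therefore estimated at 40000 nM, within a range of 12000 nM to 130000 nM.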

Compound 4, half-maximal inhibitory concentration: > 100000 nM
Compound 4: no number, only a limit; the forecaster's own chance of this, stated with the estimate: 25%; middle value at least 2.5-fold (0.39 log units) from the limit.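

In this assay, among these compounds, this is the first pair that differs in one place only: 4-chlorophenyl in place of 3-chlorophenyl on the amide-type nitrogen gives an at least 1.9-fold higher number from compound 2 to compound 4 (0.27 log units; that floor lies within the scatter). The two groups count the same atoms, so this pair tests only where the chlorine sits on the ring. Compound 4 gives only a limit, so the step has a floor but no measured size: the limit of > 100000 nM in this assay, at which 2 of the 4 values shown sit.

Going by these compounds, whether the full step lies beyond the scatter stays open. Also open, on these data alone, is whether an amine or a carboxylic acid on this phenyl ring, in place of chlorine, would give a number rather than a limit.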